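Amino for phenyl on a diaryl pyrimidine core

A few compounds are considered here, and "the series" means these few. Any claim that something is new, unique, unknown or untested is made for them only; others in the source may bear on it.

The measured compounds:
compound 1, `C#CCOc1ccc(-c2cc(-c3ccc(OCC#C)cc3)nc(N)n2)cc1`, 3300 nM
compound 2, `C#CCOc1ccc(-c2cc(-c3ccc(OCC#C)c(OCC)c3)nc(N)n2)cc1`, 14000 nM
compound 3, `C#CCOc1ccc(-c2cc(-c3ccc(OCC#C)c(OC)c3)nc(-c3ccccc3)n2)cc1`, 15700 nM

In an assay on BTI-TN-5B1-4 cells for inhibition of Amine oxidase [flavin-containing] B (Homo sapiens), read by fluorescence and Amplex Red, using microsomes, with a stated time of 30 min (a lower number here means a stronger inhibitor, a higher number a weaker inhibitor), compound 3 gives 15700 nM, the highest of the three numbers. Its nearest neighbour is compound 2, whose value sits within the scatter of it; compound 1 lies furthest away, and that gap is beyond the scatter. Compound 4, `C#CCOc1ccc(-c2cc(-c3ccc(OCC#C)c(OC)c3)nc(N)n2)cc1`, differs from compound 3 in one place: amino in place of phenyl on an aromatic carbon. For the measured compounds named here, no measured step covers this exchange. Going by the values given here, the only measured step, a 4.2-fold higher number from compound 1 to compound 2 (0.63 log units; beyond the scatter), concerns the ring that carries the propargyloxy group and not the place changed here; it shows that an added alkoxy group raised the number. Compound 4 resembles compound 2, with methoxy where compound 2 has ethoxy, and compound 2 and compound 3 give numbers within the scatter of each other. Compound 4 is therefore expected to stay close to compound 3, with a step of a 1.4-fold lower number from compound 3 to compound 4 (0.15 log units; within the scatter) that should not exceed the scatter. Compound 4 is estimated at 11000 nM, in a range from 3500 nM to 35000 nM.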

Compound 4, half-maximal inhibitory concentration: 20000 nM
Compound 4: middle estimate off by 1.8-fold (0.26 log units), on the low side, and the stated range covers the measured number.
By their numbers in this assay, from the lowest: compound 1; then compounds 2, 3 and 4 (each within the scatter of the next).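

In this assay, the exchange of phenyl for amino on the aromatic carbon between two ring nitrogen atoms gives a 1.3-fold higher number from compound 3 to compound 4 (0.11 log units; within the scatter), so this assay does not tell the six-carbon phenyl from the single-nitrogen amino at this position when the methoxy group is present. The alkoxy group on the other ring separates the compounds more clearly: adding methoxy gives a 6.1-fold higher number from compound 1 to compound 4 (0.78 log units; beyond the scatter), beyond the scatter and in the same direction as the ethoxy step, while the methoxy and ethoxy compounds do not separate, with a 1.4-fold higher number from compound 2 to compound 4 (0.15 log units; within the scatter). Among these amino compounds, then, the presence of an added alkoxy group counts for more than whether it is methoxy or ethoxy, and nothing available here explains either result.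

Going by these compounds, how a dimethylamino group, a methyl group or a hydrogen on that same carbon would compare with amino and phenyl remains open. On these data alone, it is also open whether amino and phenyl would still read alike on the core of compound 1, which has no added alkoxy group.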